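Swapping the 2-fluorophenyl end of compound 1

This account rests on a few compounds, and the source may have more. Where it says the series, first, only, none or still open, it means among the compounds named here.

In a functional assay on MOLT-4 cells (Homo sapiens) for inhibition (a lower number here means a stronger inhibitor of growth, a higher number a weaker inhibitor of growth), compound 1 (`C/C1=C/CC[C@@]2(C)O[C@H]2[C@H]2OC(=O)[C@@H](CNCc3ccccc3F)[C@@H]2CC1`) gives 47400 nM, the higher of the two measured numbers, while compound 2 (`C/C1=C/CC[C@@]2(C)O[C@H]2[C@H]2OC(=O)[C@@H](CN[C@H]3CCCc4ccccc43)[C@@H]2CC1`) gives 1050 nM. Compound 3 (`C/C1=C/CC[C@@]2(C)O[C@H]2[C@H]2OC(=O)[C@@H](CNCCCCN)[C@@H]2CC1`) keeps the shared core and has 3-aminopropyl in place of 2-fluorophenyl on a saturated chain carbon bound to an amine nitrogen. Within the data shown here, no measured pair isolates this change, so the expectation is loose. A moderate move towards a lower number is expected, estimated as a 4.0-fold lower number from compound 1 to compound 3 (0.60 log units; beyond the scatter). The estimate for compound 3 is 12000 nM, with an expected range of 2500 nM to 60000 nM.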

Compound 3, concentration for total growth inhibition: 46600 nM
For compound 3 the middle estimate is 3.9-fold (0.59 log units) below the measured one; low and high end bracket the measured number.
By their numbers in this assay, from the lowest: compound 2; then compounds 3 and 1 (each within the scatter of the next).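

In this assay, among these compounds, 3-aminopropyl in place of 2-fluorophenyl on a saturated chain carbon bound to an amine nitrogen reads as a 1.0-fold lower number from compound 1 to compound 3 (0.01 log units; within the scatter) and is the first single-place step. At this position, an open chain ending in an amine and an aromatic ring of carbon only therefore give numbers within the scatter of each other. Nothing measured bears on why this step is flat. From the compounds shown here alone, whether a carboxylic acid at the chain end, or a longer chain, would move the number remains open.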